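This account rests on a few compounds, and the source may have more. Where it says the series, first, only, none or still open, it means among the compounds named here.

Three compounds share one core and differ only in the group on an amine nitrogen. In a functional assay on Ehrlich cells (Mus musculus) for cytotoxicity, read by trypan blue exclusion, with a stated time of 2 h, tested at 25 ug/mL (a higher number here means a stronger effect of the compound at the concentration tested, a lower number a weaker effect), compound 1 `N#CC1=C(NC(=S)Nc2ccc(Br)cc2)N(c2ccc(S(N)(=O)=O)cc2)C2=C(C(=O)CCC2)C1c1ccc(Cl)cc1Cl` gives 50%. Compound 2 `N#CC1=C(NC(N)=O)N(c2ccc(S(N)(=O)=O)cc2)C2=C(C(=O)CCC2)C1c1ccc(Cl)cc1Cl` gives 35% in this assay, and compound 3 `N#CC1=C(NC(=O)CCC(=O)O)N(c2ccc(S(N)(=O)=O)cc2)C2=C(C(=O)CCC2)C1c1ccc(Cl)cc1Cl` gives 35% in this assay. Compound 3 thus stands level with compound 2, the two together the lowest of the three numbers, while a number 15 percentage points lower from compound 1 to compound 3 (beyond the scatter). Compound 4 `N#CC1=C(NS(=O)(=O)c2ccc(Br)cc2)N(c2ccc(S(N)(=O)=O)cc2)C2=C(C(=O)CCC2)C1c1ccc(Cl)cc1Cl` has not yet been measured. Compared with compound 3, the change is (4-bromophenyl)sulfonyl in place of (2-carboxyethyl)carbonyl on an amine nitrogen. The measured step that bears most on this is a number 15 percentage points lower from compound 1 to compound 3 (beyond the scatter), where a group carrying a six-membered aromatic ring with bromine gave way to (2-carboxyethyl)carbonyl; the step of no change at the digits printed from compound 2 to compound 3 (within the scatter) shows that swapping one small chain for another left the number where it was. Compound 4 brings such a ring back, though the entering (4-bromophenyl)sulfonyl is not the same group that left in compound 1, so only a partial return is expected, a number 10 percentage points higher from compound 3 to compound 4 (within the scatter). Compound 4 is therefore expected to give about 45% in this assay, within 30% to 60%.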

Compound 4, a percentage reported as activity, at one concentration (the size of the read-out at that concentration, not a potency): 90%
Estimate against measurement, compound 4: 45 percentage points below; the measured number lies above the stated range.
By their numbers in this assay, from the lowest: compounds 2 and 3 (each within the scatter of the next); then compound 1; then compound 4.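

In this assay, for the compounds shown here, the group on this amine nitrogen can move the number much further than the earlier compounds showed: (4-bromophenyl)sulfonyl gives a number 55 percentage points higher from compound 3 to compound 4 (beyond the scatter) and a number 55 percentage points higher from compound 2 to compound 4 (beyond the scatter), both large steps. A bromine-bearing aromatic ring alone does not account for this, as the group in compound 1 also carries one, yet the change to (4-bromophenyl)sulfonyl gives a number 40 percentage points higher from compound 1 to compound 4 (beyond the scatter), so what joins that ring to the nitrogen makes a difference to the number. No measurement here explains why the number rises so far.

From the compounds shown here alone, what a sulfonyl group carrying a plain phenyl ring or a methyl group would give remains open, so the shares of the sulfonyl link and the bromine cannot yet be separated. Going by these compounds, each number is also a single reading at one concentration, so how the compounds compare at other concentrations remains open too.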